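This account rests on a few compounds, and the source may have more. Where it says the series, first, only, none or still open, it means among the compounds named here.

Measured compounds in an assay on LtK cells with ATP-sensitive inward rectifier potassium channel 11 (Homo sapiens) as the target; on this read-out higher numbers stand for an effect only at larger amounts of compound and lower numbers for an effect already at smaller amounts: compound 1, `CCC(=O)Nc1c(C(O)(C(F)(F)F)C(F)(F)F)ccc2ccccc12`, gives 15 nM; compound 2, `O=C(Nc1c(C(O)(C(F)(F)F)C(F)(F)F)ccc2ccccc12)c1ccco1`, gives 9 nM.

Among these two numbers compound 2 has the lower one, yet the only step measured, a 1.7-fold lower number from compound 1 to compound 2 (0.22 log units; within the scatter), lies within the scatter, so the two compounds cannot be told apart on this assay. That step swapped a short chain for a five-membered aromatic ring on the carbonyl carbon of the amide.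

Compound 3, `O=C(Nc1c(C(O)(C(F)(F)F)C(F)(F)F)ccc2ccccc12)c1cccs1`, differs from compound 2 in a smaller way: thiophen-2-yl in place of furan-2-yl on a carbonyl carbon. The ring keeps its size, its single hetero atom and its count of donors and acceptors; only the kind of hetero atom changes. Going by the values given here, no measured pair shows this exact exchange, so the one step on record bears on it only loosely: if even a chain-to-ring change stayed within the scatter, an oxygen-to-sulfur exchange within the ring is expected to stay within it too. The expected step is a 1.1-fold higher number from compound 2 to compound 3 (0.05 log units; within the scatter), with no clear direction. Compound 3 is therefore estimated at 10 nM, with a range from 4 nM to 25 nM.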

Compound 3, half-maximal effective concentration: 12 nM
Compound 3: the middle estimate sits 1.2-fold (0.08 log units) below what was measured; low and high end bracket the measured number.
By their numbers in this assay, from the lowest: compounds 2, 3 and 1 (each within the scatter of the next).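

In this assay, exchanging the oxygen of the ring for sulfur, with thiophen-2-yl in place of furan-2-yl on the carbonyl carbon, gives the step of a 1.3-fold higher number from compound 2 to compound 3 (0.12 log units; within the scatter) and so leaves the two rings indistinguishable on this read-out. The direct comparison with the ethyl compound, the step of a 1.3-fold lower number from compound 1 to compound 3 (0.10 log units; within the scatter), adds a second five-membered aromatic ring that cannot be told apart from the short chain, so the earlier result no longer rests on the furan-2-yl ring alone. At this position, on a carbonyl carbon whose other neighbour is an amide-type nitrogen, all three groups now give numbers within the scatter of one another, and no measurement on hand explains this sameness.

These three compounds leave open how far this insensitivity reaches, for instance whether a phenyl ring, a longer chain, an amine or a carboxylic acid on the same carbonyl carbon would give a step beyond the scatter. They also leave open whether the amide hydrogen or the rest of the shared core matters more for this number than the group varied here.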